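Adding a ring hydroxy to a fluorophenyl dienone

The source may hold more compounds than are shown below. What is called first, only, known or untested is meant among the compounds shown, and "the series" means these compounds.

Measured compounds:
compound 1 `CC1=C(/C=C/C(=O)/C=C/c2ccccc2F)C(C)(C)CCC1` — 10700 nM
compound 2 `CC1=C(/C=C/C(=O)/C=C/c2ccc(F)cc2)C(C)(C)CCC1` — 7300 nM
compound 3 `CC1=CCCC(C)(C)C1/C=C/C(=O)/C=C/c1cc(C(F)(F)F)ccc1F` — 1700 nM

In a functional assay on LNCaP cells (Homo sapiens) for cytotoxicity, read by MTT assay, with a stated time of 72 h (a higher number here means a weaker inhibitor, a lower number a stronger inhibitor), compound 2 gives 7300 nM, the second highest number of the three. Its nearest neighbour is compound 1, and the step of a 1.5-fold lower number from compound 1 to compound 2 (0.17 log units; within the scatter) lies within the scatter, so the two cannot be ranked against each other. Compound 3, which carries a different aryl ring, gives 1700 nM, a lower number than compound 2 by more than the scatter.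

Compound 4 `CC1=C(/C=C/C(=O)/C=C/c2ccc(F)cc2)C(C)(C)CCC1O` differs from compound 2 in one place: hydroxy in place of hydrogen on a saturated ring carbon. Among the measured compounds shown here, the only measured step, from compound 1 to compound 2, concerns the position of a fluorine on the aryl ring and says nothing about a change on the saturated ring. For the measured compounds named here, no measured step bears on adding a hydroxy there, so no direction can be taken from the data; the expectation is a step of no clear size beyond the scatter in this assay. The estimate for compound 4 is therefore 8000 nM, with a range from 2500 nM to 25000 nM. That estimate means an expected step of a 1.1-fold higher number from compound 2 to compound 4 (0.04 log units; within the scatter).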

Compound 4, half-maximal inhibitory concentration: 3900 nM
The estimate for compound 4 lay 2.1-fold (0.31 log units) above the measured number, within the range that was stated.
By their numbers in this assay, from the lowest: compound 3; then compounds 4, 2 and 1 (each within the scatter of the next, the first and the last beyond it).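

On a saturated ring carbon, next to the ring atom that bears a methyl group, hydroxy in place of hydrogen gives in this assay a 1.9-fold lower number from compound 2 to compound 4 (0.27 log units; within the scatter), so the two compounds cannot be ranked against each other. Among the compounds shown here, the one earlier step concerned where a fluorine sits on the aryl ring, whereas this step reaches the saturated ring and shows that, with this 4-fluorophenyl group and in this assay, the ring carbon can carry a hydroxy without a step beyond the scatter. Nothing shown explains this result.

As far as these compounds go, whether a methoxy, an amine or a carboxylic acid on the same ring carbon would give a step beyond the scatter remains open. So does whether hydroxy would give a similar step alongside the aryl ring of compound 3.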